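Swapping Nitro for Bromo on an Aryl Triazene

The compounds below may be only part of what the source reports. "The series", "measured", "known", "first", "only" and "open" are said of these compounds alone.

Measured so far:
compound 1, `O=[N+]([O-])c1ccc(/N=N/N2CCCC2)cc1`: 90000 nM
compound 2, `CN(C)CCCN(/N=N/c1cc(F)ccc1F)c1ccccc1`: 7000 nM

Both compounds were tested in an ADME assay on Vero cells (Chlorocebus sabaeus) for cytotoxicity, read by crystal violet staining; on this read-out higher numbers stand for lower toxicity in this test and lower numbers for higher toxicity in this test. Compound 1 gives the higher of the two numbers, 90000 nM, while compound 2 gives 7000 nM, and this gap lies beyond the usual scatter. The two compounds differ in many places at once, so no single structural cause can be read from them.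

Compound 3, `Brc1ccc(/N=N/N2CCCC2)cc1`, has not yet been measured in this assay. It differs from compound 1 in one place: bromo in place of nitro on an aromatic carbon. Nothing measured here shows how this change affects the read-out, so the expectation rests on compound 1 alone. For compound 3 the expected step is a 1.8-fold lower number from compound 1 to compound 3 (0.26 log units; within the scatter), a small move toward a lower number, not clearly beyond the scatter. Compound 3 is therefore expected to give 50000 nM, with a range from 15000 nM to 150000 nM.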

Compound 3, half-maximal cytotoxic concentration: >= 100000 nM
Compound 3 was reported as a limit (the forecaster's own chance of this, stated with the estimate: 15%); middle value at least 2.0-fold (0.30 log units) from the limit.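

In this assay, compound 3 gives >= 100000 nM, which is a limit of the assay and not an exact number. Bromo in place of nitro on this aromatic carbon gives an at least 1.1-fold higher number from compound 1 to compound 3 (0.04 log units; that floor lies within the scatter), so on this core the nitro group is not needed to keep toxicity in this test low. How large the step really is cannot be read, because of one feature of the data: the limit of >= 100000 nM in this assay, at which 1 of the 3 values shown sits.

The compounds shown leave open whether other groups on this aromatic carbon, such as an amine or a carboxylic acid, would also keep the number this high. They also leave open whether bromo would behave the same way on a different core, such as that of compound 2.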